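Methyl ester versus free acid on two related cores

A few compounds are considered here, and "the series" means these few. Any claim that something is new, unique, unknown or untested is made for them only; others in the source may bear on it.

Values in an assay for inhibition of Fatty-acid amide hydrolase 1 (Rattus norvegicus); a lower number here means a stronger inhibitor, a higher number a weaker inhibitor:
compound 1 `COC(=O)c1cc(-c2cnc(C(=O)CCc3ccc(-c4ccccc4)cc3)o2)ccn1`: 1.5 nM
compound 2 `O=C(O)c1cc(-c2cnc(C(=O)CCc3ccc(-c4ccccc4)cc3)o2)ccn1`: 50 nM
compound 3 `O=C(O)c1ccc(-c2cnc(C(=O)CCc3ccc(COc4ccccc4)cc3)o2)nc1`: 4.6 nM

Compound 2 to compound 1 is a single change, (methyl in place of hydrogen on an oxygen next to a carbonyl group), and it gave a 33-fold lower number from compound 2 to compound 1 (1.52 log units; beyond the scatter). Compound 4 `COC(=O)c1ccc(-c2cnc(C(=O)CCc3ccc(COc4ccccc4)cc3)o2)nc1`, not yet measured, stands to compound 3 in the same way, (methyl in place of hydrogen on an oxygen next to a carbonyl group). The two "place" descriptions read identically, but the difference between the cores of compound 2 and compound 3 is not broken down here, so this is treated as the same kind of change rather than the same one. In this assay compound 3 lies between compound 1 and compound 2. Among the measured compounds shown here, a step of a 15-fold lower number from compound 3 to compound 4 (1.19 log units; beyond the scatter) is expected from compound 3 to compound 4, somewhat smaller than the earlier one because the only precedent is a 33-fold lower number from compound 2 to compound 1 (1.52 log units; beyond the scatter) on a different core. Compound 4 is estimated at 0.3 nM, expected between 0.08 nM and 1.2 nM.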

Compound 4, inhibition constant: 3.5 nM
Beside the measured number, compound 4's estimate is 12-fold (1.07 log units) below it; the measured number lies above the stated range.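

In this assay, the methyl-for-hydrogen change on the oxygen next to the carbonyl group gives a 1.3-fold lower number from compound 3 to compound 4 (0.12 log units; within the scatter), so the large step seen on the core of compound 1 does not carry over in size to the core of compound 4: the same change on two cores in this assay, a 33-fold lower number (1.52 log units; beyond the scatter) from compound 2 to compound 1 and a 1.3-fold lower number (0.12 log units; within the scatter) from compound 3 to compound 4, 25-fold (1.40 log units) apart, beyond the scatter of two such steps. On the core of compound 4, the carboxy and methoxycarbonyl forms cannot be told apart. Two pairs show only that the size of this step can differ with the core; they give no general rule for other cores and do not identify which difference between the cores matters.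

Which part of the core difference governs the step remains open. So does how an ethyl ester or a primary amide in place of methoxycarbonyl would read on each core.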